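This account rests on a few compounds, and the source may have more. Where it says the series, first, only, none or still open, it means among the compounds named here.

In a functional assay on T47D cells (Homo sapiens) for antiproliferative activity, read by MTT assay, with a stated time of 72 h (on this read-out higher numbers stand for weaker inhibition and lower numbers for stronger inhibition), the three measured compounds stand as follows:

compound 1, `COc1cc(-c2nccn2C)cc(OC)c1OC`: > 100000 nM, which is a limit of this assay and not a number
compound 2, `COc1cc(-c2nccn2-c2ccc3[nH]ccc3c2)cc(OC)c1OC`: 2100 nM
compound 3, `COc1cc(-c2nccn2-c2ccc(C)cc2)cc(OC)c1OC`: 20500 nM

Compound 1 therefore stands only as a range on these numbers, at the upper edge of what this assay reports, as shown by the limit of > 100000 nM in this assay, at which 1 of the 3 values shown sits. The unmeasured compound 4, `COc1cc(-c2nccn2-c2ccc(F)cc2)cc(OC)c1OC`, differs from compound 1 in one place: 4-fluorophenyl in place of methyl on an aromatic nitrogen. Among the compounds with values here, the one measured step that bears on this change is an at least 4.8-fold lower number from compound 1 to compound 3 (0.68 log units; beyond the scatter), where a 4-methylphenyl group took the same place on the aromatic nitrogen. Within the data shown here, compound 2, carrying an indolyl group at that position, gives a still lower number in this assay, but no single-place step links it to compound 1 or compound 3. A 4-fluorophenyl group on that nitrogen is expected to behave much like the 4-methylphenyl group of compound 3, so compound 4 is estimated to give a lower number than compound 1, a step of an at least 5.0-fold lower number from compound 1 to compound 4 (0.69 log units; beyond the scatter), with an estimated value of 20000 nM and a range from 6000 nM to 60000 nM in this assay.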

Compound 4, half-maximal inhibitory concentration: > 100000 nM
Compound 4: no number, only a limit; the forecaster's own chance of this, stated with the estimate: 10%; middle value at least 5.0-fold (0.69 log units) from the limit.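

In this assay compound 4 gives > 100000 nM, which is a limit of the assay and not a number. Within the data shown here, the earlier compounds showed only that a 4-methylphenyl group on the aromatic nitrogen brought a lower number than methyl, and the new result shows that this does not hold for every substituted phenyl group in that place: with fluoro in place of methyl on an aromatic carbon, there is an at least 4.8-fold higher number from compound 3 to compound 4 (0.68 log units; beyond the scatter), so the small group on the phenyl ring matters as well as the ring itself. Compound 1 and compound 4 both stand only as limits, and the step between them cannot be read: the limit of > 100000 nM in this assay, at which 2 of the 4 values shown sit.

Going by these compounds, what a chloro group or an amine would give on that same aromatic carbon stays open, so it cannot be said whether methyl is unusual there or fluoro is, and the two phenyl compounds alone define no trend. Among these compounds, how the indolyl group of compound 2 relates to these phenyl groups also stays open, as no single-place step links it to either of them.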